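Moving a Hydroxyl Across a Phenyl Ring on Two Cores

A few compounds are considered here, and "the series" means these few. Any claim that something is new, unique, unknown or untested is made for them only; others in the source may bear on it.

Compound 1, `Oc1ccccc1-c1cc(-c2ccccc2C(F)(F)F)cc(-c2ccccc2O)n1`, carries two hydroxyphenyl groups and a trifluoromethylphenyl group on its central ring. In a functional assay on DU-145 cells (Homo sapiens) for inhibition (a higher number here means a weaker inhibitor, a lower number a stronger inhibitor), compound 1 gives 4770 nM. Compound 2, `Oc1cccc(-c2cc(-c3ccccc3C(F)(F)F)cc(-c3ccccc3O)n2)c1`, differs from it by one change: 3-hydroxyphenyl in place of 2-hydroxyphenyl on an aromatic carbon. In this assay compound 2 gives 7250 nM. The step is a 1.5-fold higher number from compound 1 to compound 2 (0.18 log units; within the scatter), so the two values cannot be told apart.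

Compound 3, `Oc1cccc(-c2cc(-c3cccc(OC(F)(F)F)c3)cc(-c3ccccc3O)n2)c1`, has a different core; how its core differs from that of compound 1 is not broken down here. In this assay compound 3 gives only a limit of the assay, > 50000 nM. This is the limit of > 50000 nM in this assay, at which 1 of the 3 values shown sits.

Compound 4, `Oc1cccc(-c2cc(-c3cccc(OC(F)(F)F)c3)cc(-c3cccc(O)c3)n2)c1`, is not yet measured and differs from compound 3 by 3-hydroxyphenyl in place of 2-hydroxyphenyl on an aromatic carbon. This is the same kind of change as from compound 1 to compound 2, not the same change: in the earlier pair the carbon was meta to a 2-(trifluoromethyl)phenyl group and meta to a 2-hydroxyphenyl group, whereas here it is meta to a 3-hydroxyphenyl group and meta to a large group.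

Compound 4 is expected to show a step that the limit leaves unreadable from compound 3 to compound 4 in this assay, an expectation that rests on the earlier 1.5-fold higher number from compound 1 to compound 2 (0.18 log units; within the scatter). Since compound 3 already sits at the limit of > 50000 nM in this assay, at which 1 of the 3 values shown sits, compound 4 is expected to give 75000 nM, with a range from 30000 nM to 200000 nM, most likely reported again only as a limit.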

Compound 4, half-maximal inhibitory concentration: > 50000 nM
Compound 4: only a limit was reported (the forecaster's own chance of this, stated with the estimate: 80%); the middle value is on the limit's open side.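

In this assay, compound 3 and compound 4 are each reported only as a limit of the assay, and no step between them can be read because both sit at that same limit: the limit of > 50000 nM in this assay, at which 2 of the 4 values shown sit.

The compounds shown leave open how strong an inhibitor compound 3 or compound 4 really is, and whether 3-hydroxyphenyl in place of 2-hydroxyphenyl makes any difference on their core.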